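The source may report more compounds than this note shows. Statements on the series, on what has been measured and on what is new or still open speak of the compounds shown alone.

Measured compounds:
- compound 1, `O=C(Nc1ncc(Cc2cccc3c2CCCC3)s1)C1CCCCC1`: "not determined" (no result reported)
- compound 2, `O=C(c1cnc(NC(=O)C2CCCCC2)s1)c1cccc2ccccc12`: > 40000 nM
- compound 3, `O=C(Nc1ncc(Cc2ccnc3ccccc23)s1)C1CCCCC1`: 13900 nM

In an ADME assay on P388D1 cells (Mus musculus) for cytotoxicity, read by fluorescence and resazurin assay, with a stated time of 72 h (on this read-out higher numbers stand for weaker inhibition and lower numbers for stronger inhibition), compound 1 has no number; its result there is "not determined" (no result reported). Compound 2 gives only a limit of the assay, > 40000 nM, which is the limit of > 40000 nM in this assay, at which 1 of the 3 values shown sits. Among the measured compounds shown here, compound 3, the one compound with a measured number, gives 13900 nM, a weak effect on these cells. So compound 1 stands without a number of its own, among close relatives that are weak or beyond what this assay can resolve.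

Compound 4, `O=C(CCC1CCCCC1)Nc1ncc(Cc2cccc3c2CCCC3)s1`, differs from compound 1 in one place: 2-cyclohexylethyl in place of cyclohexyl on a carbonyl carbon. For the measured compounds named here, no measured pair shows what such a change does in this assay, so the size of the step from compound 1 to compound 4 is expected to be none beyond the usual scatter, in no particular direction. On the strength of the weak values of compound 2 and compound 3, compound 4 is expected to give about 20000 nM in this assay, estimated to lie between 7000 nM and 45000 nM.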

Compound 4, half-maximal inhibitory concentration: 24300 nM
Compound 4: the middle estimate sits 1.2-fold (0.08 log units) below what was measured; the range from low to high includes it.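

Compound 1 has no number in this assay, so compound 4 at 24300 nM has nothing to be set against, and no step can be read. The compounds shown leave open whether 2-cyclohexylethyl in place of cyclohexyl changes the effect on these cells at all, and in which direction.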